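Imidazole for Benzimidazole on a Pentyl-Linked Aryl Piperazine

The source may hold more compounds than are shown below. What is called first, only, known or untested is meant among the compounds shown, and "the series" means these compounds.

Compound 1 `O=c1ccc(-n2cnc3ccccc32)nn1CCN1CCN(c2ccccc2Cl)CC1`, compound 2 `O=c1ccc(-n2cnc3ccccc32)nn1CCCCCN1CCN(c2ccccc2Cl)CC1` and compound 3 `O=c1ccc(-n2ccnc2)nn1CCN1CCN(c2ccccc2Cl)CC1` were examined in an assay on cell membranes from brain for binding affinity to Adrenergic receptor alpha-1 (Rattus norvegicus), read by radioligand binding; a higher number here means a weaker inhibitor, a lower number a stronger inhibitor. In this assay compound 1 gives 70.4 nM, compound 2 gives 4.5 nM and compound 3 gives 472 nM, the lowest of the three numbers. The difference between the cores of compound 1 and compound 2 is not broken down here. Putting 1H-imidazol-1-yl in place of 1H-benzimidazol-1-yl on an aromatic carbon gave a 6.7-fold higher number from compound 1 to compound 3 (0.83 log units; beyond the scatter). Compound 4 `O=c1ccc(-n2ccnc2)nn1CCCCCN1CCN(c2ccccc2Cl)CC1` has not yet been measured; it differs from compound 2 by the same change, (1H-imidazol-1-yl in place of 1H-benzimidazol-1-yl on an aromatic carbon), and the surroundings of the place are described in the same words. Because compound 1 and compound 3 showed a 6.7-fold higher number from compound 1 to compound 3 (0.83 log units; beyond the scatter), a step of a 6.7-fold higher number from compound 2 to compound 4 (0.82 log units; beyond the scatter) in this assay is expected for compound 4. Compound 4 is therefore estimated at 30 nM, with a likely range from 10 nM to 90 nM.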

Compound 4, inhibition constant: 23.3 nM
The estimate for compound 4 lay 1.3-fold (0.11 log units) above the measured number; the range from low to high includes it.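

Putting 1H-imidazol-1-yl in place of 1H-benzimidazol-1-yl gave a 5.2-fold higher number from compound 2 to compound 4 (0.71 log units; beyond the scatter) in this assay, and the step set beside the earlier one on the other core reads as follows: the same change on two cores in this assay, a 6.7-fold higher number (0.83 log units; beyond the scatter) from compound 1 to compound 3 and a 5.2-fold higher number (0.71 log units; beyond the scatter) from compound 2 to compound 4, 1.3-fold (0.11 log units) apart, within the scatter of two such steps. The change thus carried over from one core to the other in this series with no size difference that can be told apart. This rests on two cores and one assay, so it does not show that the step would hold on any further core or in another assay, and it gives no reason for the rise.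

Still open, from the compounds shown here alone, is what a simple amine or a carboxylic acid would do on that aromatic carbon. Also open, going by these compounds, is whether the step would survive on a core with a longer chain than pentyl.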